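The compounds below may be only part of what the source reports. "The series", "measured", "known", "first", "only" and "open" are said of these compounds alone.

Compound 1 `Cc1ccc2c(NCc3ccc(NC(=O)C4CCN(Cc5ccccc5)CC4)cc3)nc(N3CCC3)nc2c1` was tested in a functional assay on SV5A8 cells (Homo sapiens) for cytotoxicity (a lower number here means a stronger inhibitor, a higher number a weaker inhibitor), and there compound 1 gives > 8500 nM. That value is a limit of the assay and not a number. Within the data shown here, the only other measured compound is compound 2 `Cc1ccc2c(NCc3ccc(NC(=O)C4CCN(Cc5ncc[nH]5)CC4)cc3)nc(N(C)C)nc2c1`, and in this assay compound 2 gives > 20000 nM. That, too, is a limit and not a number. Of the two values shown, one sits at the limit of > 8500 nM in this assay, at which 1 of the 2 values shown sits, and one at the limit of > 20000 nM in this assay, at which 1 of the 2 values shown sits, so compound 1 stands at a limit with no exact number of its own. Among the measured compounds shown here, no step between measured compounds has been worked out, and compound 2 differs from compound 1 in more than one place, so their two values show only that neither reaches a number. Compound 3 `CCN1CCN(c2nc(NCc3ccc(NC(=O)C4CCN(Cc5ccccc5)CC4)cc3)c3ccc(C)cc3n2)CC1` has not yet been measured. It carries 4-ethylpiperazin-1-yl in place of azetidin-1-yl on an aromatic carbon, that is, 4-ethylpiperazin-1-yl in place of azetidin-1-yl on an aromatic carbon. With both measured compounds at limits, no step beyond the scatter is expected in this assay in either direction. Compound 3 is therefore estimated at 15000 nM, between 4000 nM and 60000 nM. That estimate means an expected step that the limit leaves unreadable from compound 1 to compound 3, which is an expectation rather than a known result.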

Compound 3, half-maximal inhibitory concentration: > 13000 nM
Compound 3: only a limit was reported; the forecaster's own chance of this, stated with the estimate: 75%; the middle value does not contradict the limit.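

In this assay, compound 1 and compound 3 are both reported only as limits and not as numbers, so no step can be read for 4-ethylpiperazin-1-yl in place of azetidin-1-yl. The compounds shown leave open what exact value any of them has in this assay, and whether this change of group affects that value at all.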